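Replacing 1H-imidazol-1-yl with piperidin-1-yl in compound 4

The source may report more compounds than this note shows. Statements on the series, on what has been measured and on what is new or still open speak of the compounds shown alone.

Measured in a functional assay on MCF7 cells (Homo sapiens) for antiproliferative activity, read by CellTiter-Glo, with a stated time of 5 days; on this read-out lower numbers stand for stronger inhibition and higher numbers for weaker inhibition:
- Compound 1 `CC/C(=C(/c1ccc(/C=C/C(=O)O)cc1)c1ccc(-c2cscn2)cc1)c1ccccc1`: 120 nM
- Compound 2 `CC/C(=C(/c1ccc(/C=C/C(=O)O)cc1)c1ccc(-c2nccs2)cc1)c1ccccc1`: 290 nM
- Compound 3 `CC/C(=C(/c1ccc(/C=C/C(=O)O)cc1)c1ccc(-n2ccnc2)cc1)c1ccccc1`: 380 nM

In this assay, compound 3 cannot be told apart from compound 2, as a 1.3-fold higher number from compound 2 to compound 3 (0.12 log units; within the scatter) shows, but it is separated from compound 1 by a 3.2-fold higher number from compound 1 to compound 3 (0.50 log units; beyond the scatter). Compound 4 `CC/C(=C(/c1ccc(/C=C/C(=O)O)cc1)c1ccc(N2CCCCC2)cc1)c1ccccc1` carries piperidin-1-yl in place of 1H-imidazol-1-yl on an aromatic carbon, para to a large group: piperidin-1-yl in place of 1H-imidazol-1-yl on an aromatic carbon. The three measured steps all exchange one five-membered aromatic ring for another at this place. Besides the two above, there is a 2.4-fold higher number from compound 1 to compound 2 (0.38 log units; beyond the scatter), so these exchanges have been modest or within the scatter. None of them introduces a six-membered non-aromatic ring, so the data give no direct guide to this change and only weak support for any direction. A small step is therefore expected, with a slight lean towards a higher number and a wide margin. The estimate means a 1.2-fold higher number from compound 3 to compound 4 (0.07 log units; within the scatter), and no step beyond the scatter is expected. Compound 4 is expected at 450 nM, with an estimated range of 150 nM to 1300 nM.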

Compound 4, half-maximal inhibitory concentration: 450 nM
Beside the measured number, compound 4's estimate shows no gap at the digits printed; low and high end bracket the measured number.
By their numbers in this assay, from the lowest: compound 1; then compounds 2, 3 and 4 (each within the scatter of the next).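

In this assay, a non-aromatic ring at this place gives a number that cannot be told apart from those of two five-membered aromatic rings: piperidin-1-yl stays within the scatter of 1H-imidazol-1-yl (a 1.2-fold higher number from compound 3 to compound 4 (0.07 log units; within the scatter)) and of 1,3-thiazol-2-yl (a 1.6-fold higher number from compound 2 to compound 4 (0.19 log units; within the scatter)). Only the 1,3-thiazol-4-yl of compound 1 stands apart (a 3.8-fold higher number from compound 1 to compound 4 (0.57 log units; beyond the scatter)), so among these four compounds an aromatic ring at this place does not by itself set the number apart. Nothing measured here explains these numbers.

From the compounds shown here alone, it remains open whether an open-chain amine such as dimethylamino, or a morpholin-4-yl ring, would fall with compounds 2, 3 and 4 or nearer to compound 1. Going by these compounds, it also remains open whether a substituent such as methyl on the 1,3-thiazol-4-yl ring would change the number of compound 1.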